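This account rests on a few compounds, and the source may have more. Where it says the series, first, only, none or still open, it means among the compounds named here.

Compound 1 `CC(=O)OCCc1c(C)nc(Cl)nc1Cl` was tested in a functional assay on HCT-116 cells (Homo sapiens) for antiproliferative activity, read by MTT assay, with a stated time of 24 h; a higher number here means a weaker inhibitor, a lower number a stronger inhibitor. In this assay compound 1 gives > 100000 nM, which is a limit of the assay and not a number. Compound 2 `COc1nc(Cl)nc(C)c1CCOC(C)=O`, in which a methoxy replaces a chloro on an aromatic carbon, stands alongside it. In this assay compound 2 gives > 100000 nM, likewise a limit and not a number. The step that the two limits leave unreadable from compound 1 to compound 2 cannot be read, since both ends rest at the same limit; the only thing the measured record shows is the limit of > 100000 nM in this assay, at which 2 of the 2 values shown sit.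

Compound 3 `Cc1nc(Cl)nc(Cl)c1CCCl` differs from compound 1 by chloro in place of acetoxy on a saturated chain carbon, two bonds along the chain from an aromatic carbon. Among the compounds with values here, no measured step touches the acetoxy group or the chain it sits on, so nothing among the measured pairs speaks to the size or direction of this change. What the record does show is that the shared core of compound 1 and compound 2 has not yet given a readable value in this assay, and compound 3 keeps that core unchanged. Compound 3 is therefore expected to stay near the same limit, with an estimated step that the limit leaves unreadable from compound 1 to compound 3 and an estimated value of 150000 nM, within a range from 40000 nM to 600000 nM.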

Compound 3, half-maximal inhibitory concentration: 2000 nM
Estimate against measurement, compound 3: 75-fold (1.88 log units) above, and the stated range ends above it.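

In this assay, the chain position turns out to be where the readout moves: chloro in place of acetoxy on a saturated chain carbon, two bonds along the chain from an aromatic carbon, gives an at least 50-fold lower number from compound 1 to compound 3 (1.69 log units; beyond the scatter). Within the data shown here, the earlier compounds could not show this, as their one step cannot be read and neither touches the chain, whereas compound 3 gives 2000 nM, the first readable value for the shared core. The core of compound 1 therefore does not by itself hold a compound at the limit, and compound 3 is the only one of the three to come off it: the limit of > 100000 nM in this assay, at which 2 of the 3 values shown sit.

The compounds shown leave open whether this step belongs to the arriving chloro or to the departing acetoxy, and a hydroxyl, an amine or a bromo on the same chain carbon would help to separate those two readings. They also leave open how far the result depends on the length of the chain, which a longer chain ending in chloro would address, and whether a methoxy in place of chloro on an aromatic carbon of compound 3 would keep a readable value.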